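Indole for phenyl on the triazole: expected effect

The source may hold more compounds than are shown below. What is called first, only, known or untested is meant among the compounds shown, and "the series" means these compounds.

Measured compounds in a functional assay on MCF7 cells (Homo sapiens) for antiproliferative activity; a lower number here means a stronger inhibitor, a higher number a weaker inhibitor:
compound 1 `Cc1c(O)ccc2cc(-n3cc(-c4ccccc4)nn3)c(=O)oc12` gives 25200 nM
compound 2 `CC(=O)Oc1ccc2cc(-n3cc(-c4ccccc4)nn3)c(=O)oc2c1C` gives 40800 nM
compound 3 `COc1cccc(-c2cc(-c3cn(-c4cc5ccc(O)c(C)c5oc4=O)nn3)ccc2OC)c1` gives 28000 nM

Compound 2 shows the highest of the three numbers, but none of the gaps is more than scatter: the step of a 1.6-fold higher number from compound 1 to compound 2 (0.21 log units; within the scatter) is within the scatter, and the values of compound 2 and compound 3 also lie within the scatter of each other. On these numbers compound 2 is not separated from compound 1 or compound 3.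

Compound 4 `CC(=O)Oc1ccc2cc(-n3cc(-c4cc5ccccc5[nH]4)nn3)c(=O)oc2c1C` differs from compound 2 in one place: 1H-indol-2-yl in place of phenyl on an aromatic carbon, on an aromatic carbon of a five-membered aromatic ring with 3 nitrogen. Among the compounds with values here, no measured step touches this position; the only measured step, a 1.6-fold higher number from compound 1 to compound 2 (0.21 log units; within the scatter), concerns the oxygen on the aromatic ring and says nothing about the group on the triazole. There is therefore no ground to expect a step beyond the scatter in this assay in either direction; the estimate for the step of a 1.3-fold lower number from compound 2 to compound 4 (0.11 log units; within the scatter) is accordingly flat, with a wide range. Compound 4 is expected to give about 32000 nM in this assay, between 8000 nM and 130000 nM.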

Compound 4, half-maximal inhibitory concentration: 76100 nM
Compound 4: the middle estimate sits 2.4-fold (0.38 log units) below what was measured; the range from low to high includes it.
By their numbers in this assay, from the lowest: compounds 1, 3, 2 and 4 (each within the scatter of the next, the first and the last beyond it).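

This is the first step shown at the group on the triazole: in this assay, 1H-indol-2-yl in place of phenyl gives a 1.9-fold higher number from compound 2 to compound 4 (0.27 log units; within the scatter). The entering group adds a five-membered aromatic ring and a hydrogen-bond donor, yet this pair shows no separation between it and phenyl. The reading rests on this single pair, which carries the acetyl on the oxygen, and nothing available bears on the underlying reason for the result.

Going by these compounds, whether the same exchange stays within the scatter with the free hydroxyl of compound 1 remains open. Also open, on these data alone, is what this position would give with a group of another kind, such as an amine or a carboxylic acid, in place of the aromatic rings.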